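Two halogenated aryl analogues and a dichlorophenyl candidate

The compounds below may be only part of what the source reports. "The series", "measured", "known", "first", "only" and "open" are said of these compounds alone.

Compound 1 `COc1ccc(Cl)cc1-n1ncc(-c2nnc(-c3ccc(F)cc3)o2)c1C` gives 4.26 in a physicochemical assay for lipophilicity, using the shake flask method, measured as octanol-water partition; on this read-out higher numbers stand for higher lipophilicity and lower numbers for lower lipophilicity.
Compound 2 `COc1ccc(Cl)cc1-n1ncc(-c2nnc(-c3ccc(Br)c(C)c3)o2)c1C` gives 5.2 in this assay.

Within the data shown here, compound 2 stands highest of the two numbers measured so far; its nearest neighbour, compound 1, sits below it, and the step of a number 0.94 log units higher from compound 1 to compound 2 (beyond the scatter) lies beyond the scatter. Compound 3 `COc1ccc(Cl)cc1-n1ncc(-c2nnc(-c3cc(Cl)cc(Cl)c3)o2)c1C` is not yet measured. The change from compound 2 to compound 3 is 3,5-dichlorophenyl in place of 4-bromo-3-methylphenyl on an aromatic carbon. Among the measured compounds shown here, only one measured step bears on this change, the step of a number 0.94 log units higher from compound 1 to compound 2 (beyond the scatter), in which a 4-fluorophenyl was exchanged for a 4-bromo-3-methylphenyl at the same position and the number rose by a modest amount. Here the exchange runs between two substituted phenyl groups of equal heavy-atom count, one carrying a bromine and a methyl, the other two chlorines, so a step of at most small size in either direction, or none beyond the scatter, is expected. Compound 3 is therefore estimated at 5.3, with a range from 4.9 to 5.7, which corresponds to an expected step of a number 0.10 log units higher from compound 2 to compound 3 (within the scatter).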

Compound 3, partition coefficient: 5.61
Beside the measured number, compound 3's estimate is 0.31 log units below it, within the range that was stated.
By their numbers in this assay, from the lowest: compound 1; then compound 2; then compound 3.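

The exchange of 4-bromo-3-methylphenyl for 3,5-dichlorophenyl, on the aromatic carbon next to the ring oxygen, shows that equal counts do not mean equal numbers in this assay: both groups have 8 heavy atoms and one six-membered aromatic ring of carbon only, and no hydrogen-bond donors or acceptors, yet the result is a number 0.41 log units higher from compound 2 to compound 3 (beyond the scatter). Compound 3 now holds the highest number of the three, with steps beyond the scatter to both other compounds, and the full span at this position widens to a number 1.35 log units higher from compound 1 to compound 3 (beyond the scatter), so the choice of substituted phenyl here can move the number by a large step while the rest of the molecule stays the same. Nothing available accounts for the order of these three compounds.

Because each exchange alters both the identity and the placement of the substituents, the compounds shown cannot separate what the chlorines contribute from where they sit, and a phenyl with a single chlorine would be needed to divide the step. From the compounds shown here alone, all three groups are also halogenated phenyls, so how a phenyl bearing an amine or a carboxylic acid would read at this position remains open.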